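The source may hold more compounds than are shown below. What is called first, only, known or untested is meant among the compounds shown, and "the series" means these compounds.

Compound 1 `CNC(=O)c1cc(Oc2ccc3nc(Nc4cccc(C(C)(C)C)c4)ccc3c2)ccn1`, compound 2 `CCc1ccccc1Nc1ncc2cc(Oc3ccnc(C(=O)NC)c3)ccc2n1` and compound 3 `CNC(=O)c1cc(Oc2ccc3nc(Nc4cccc(Cl)c4)ncc3c2)ccn1` share one core and differ only in the group carried on a nitrogen on an aromatic ring. In a physicochemical assay for solubility, at pH 7 (a higher number here means a more soluble compound, a lower number a less soluble compound), compound 1 gives only a limit, < 1000 nM. In this assay compound 2 likewise gives a limit, < 1000 nM. Compound 3 also reaches only a limit in this assay, < 1000 nM. Compound 2 thus stands at a limit, as do the two other values shown, and the step that the two limits leave unreadable from compound 2 to compound 3 cannot be read as a number; the limit of < 1000 nM in this assay, at which 3 of the 3 values shown sit, records this.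

Compound 4 `CNC(=O)c1cc(Oc2ccc3nc(Nc4ccc(F)cc4)ncc3c2)ccn1` is still to be measured. It differs from compound 2 by 4-fluorophenyl in place of 2-ethylphenyl on a nitrogen on an aromatic ring. For the measured compounds named here, the one measured step at the same position is unreadable, so it gives neither a direction nor a size; what the three values do show is that every compound so far has sat at the same limit in this assay. The expectation for compound 4 is therefore a value at or near that limit, estimated at 500 nM with a range from 100 nM to 2000 nM. The step this implies, a step that the limit leaves unreadable from compound 2 to compound 4, is expected to stay within the scatter.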

Compound 4, solubility: < 1000 nM
Compound 4 gave a limit, no number; the forecaster's own chance of this, stated with the estimate: 75%; the middle value is on the limit's open side.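

Compound 4 gives only a limit in this assay, so its steps from compound 2 and from compound 3 cannot be read as sizes: the limit of < 1000 nM in this assay, at which 4 of the 4 values shown sit. The compounds shown leave open how far under that limit each one lies, and whether the group on the nitrogen makes any difference to the read-out in this assay.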